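Swapping Methoxy for Fluoro Across Two Related Cores

This account rests on a few compounds, and the source may have more. Where it says the series, first, only, none or still open, it means among the compounds named here.

Compound 1 `COC(=O)c1c(Nc2ccc(OC)cc2)sc(C(=O)c2ccc(OC)cc2)c1C` and compound 2 `COC(=O)c1c(Nc2ccc(F)cc2)sc(C(=O)c2ccc(OC)cc2)c1C` share one core, while compound 3 `COc1ccc(Nc2sc(C(=O)c3ccc(OC)cc3)c(C)c2C(=O)O)cc1` and compound 4 `COc1ccc(C(=O)c2sc(Nc3ccc(F)cc3)c(C(=O)O)c2C)cc1` share another. The two cores differ by hydrogen in place of methyl on an oxygen next to a carbonyl group, methoxycarbonyl to carboxy. In a functional assay, with a stated time of 150 min, tested at 35 ug/mL (a higher number here means a stronger effect of the compound at the concentration tested, a lower number a weaker effect), compound 1 gives 25.1%, and compound 2 gives 25.6%; the change between them, (fluoro in place of methoxy on an aromatic carbon), made the step of a number 0.5 percentage points higher from compound 1 to compound 2 (within the scatter). Compound 3 gives 51% in this assay. Between the two cores the step is a number 25.9 percentage points higher from compound 1 to compound 3 (beyond the scatter). Compound 4 carries the same change, (fluoro in place of methoxy on an aromatic carbon), on the carboxy core, so this change has been measured once among these compounds. Because a number 0.5 percentage points higher from compound 1 to compound 2 (within the scatter) lay within the scatter, the step from compound 3 is expected to be a number 0.5 percentage points higher from compound 3 to compound 4 (within the scatter). Compound 4 is therefore expected to give 51.5% in this assay, within a range from 38% to 64%.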

Compound 4, a percentage reported as activity, at one concentration (the size of the read-out at that concentration, not a potency): 12.8%
The estimate for compound 4 lay 38.7 percentage points above the measured number; the measured number lies below the stated range.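

In this assay, fluoro in place of methoxy on an aromatic carbon gives a number 38.2 percentage points lower from compound 3 to compound 4 (beyond the scatter), so on these two cores the change does not carry over with the same size: the same change on two cores in this assay, a number 0.5 percentage points higher (within the scatter) from compound 1 to compound 2 and a number 38.2 percentage points lower (beyond the scatter) from compound 3 to compound 4, 38.7 percentage points apart, beyond the scatter of two such steps

Read the other way, hydrogen in place of methyl on an oxygen next to a carbonyl group gives a number 12.8 percentage points lower from compound 2 to compound 4 (beyond the scatter), a step in the opposite direction to the one seen with methoxy in place: the same change on two cores in this assay, a number 25.9 percentage points higher (beyond the scatter) from compound 1 to compound 3 and a number 12.8 percentage points lower (beyond the scatter) from compound 2 to compound 4, 38.7 percentage points apart, beyond the scatter of two such steps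

The two changes thus depend on each other in these four compounds, but a single pair on each core does not show whether this holds for any other group.

The compounds shown leave open whether chloro or trifluoromethyl in that place would follow methoxy or fluoro on the carboxy core. They also leave open whether an amide in place of the carboxy group would behave like the carboxy compounds.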